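A few compounds are considered here, and "the series" means these few. Any claim that something is new, unique, unknown or untested is made for them only; others in the source may bear on it.

Compound 1, `CCCCc1c(F)c(N)c2c(=O)cc(-c3ccc(N)c(F)c3)oc2c1F`, gives in a functional assay on HeLa cells (Homo sapiens) for cytotoxicity, read by neutral red uptake, with a stated time of 3 days (on this read-out lower numbers stand for stronger inhibition and higher numbers for weaker inhibition), only a limit of the assay, > 100000 nM.
Compound 2, `Nc1ccc(-c2cc(=O)c3c(N)c(F)c(O)c(F)c3o2)cc1F`, gives in this assay only a limit, > 100000 nM.
Compound 3, `CCOC(=O)c1c(F)c(N)c2c(=O)cc(-c3ccc(N)c(F)c3)oc2c1F`, gives in this assay only a limit, > 100000 nM.

Compound 1 therefore has no numeric position in this assay; its value is a limit, and the same holds for the two other measured compounds, as the limit of > 100000 nM in this assay, at which 3 of the 3 values shown sit, shows. Compound 4, `Nc1ccc(-c2cc(=O)c3c(N)c(F)c(C(=O)O)c(F)c3o2)cc1F`, differs from compound 1 by carboxy in place of butyl on an aromatic carbon. Within the data shown here, the steps that bear on this change all replace the butyl on the same aromatic carbon or alter that position: a step that the two limits leave unreadable from compound 1 to compound 2, a step that the two limits leave unreadable from compound 1 to compound 3 and a step that the two limits leave unreadable from compound 2 to compound 3. None of them is readable, because every value sits at the limit described by the limit of > 100000 nM in this assay, at which 3 of the 3 values shown sit. Nothing measured therefore points to a readable step for a carboxy at this position, and the expectation is that compound 4 again reaches only the limit in this assay, with an expected step that the limit leaves unreadable from compound 1 to compound 4. The estimate for compound 4 is 150000 nM, ranging from 60000 nM to 400000 nM.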

Compound 4, half-maximal inhibitory concentration: > 100000 nM
Compound 4 gave a limit, no number; the forecaster's own chance of this, stated with the estimate: 90%; the middle value is on the limit's open side.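

No step can be read between compound 1, compound 2, compound 3 and compound 4, since each gives only a limit and not a number: the limit of > 100000 nM in this assay, at which 4 of the 4 values shown sit.

The compounds shown leave open whether any group at this position of the shared core gives a numeric value in this assay at all.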